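A few compounds are considered here, and "the series" means these few. Any claim that something is new, unique, unknown or untested is made for them only; others in the source may bear on it.

Of the compounds shown here, two that share one core have so far been measured in a functional assay on U-87MG ATCC cells for inhibition, with U-87 MG (Homo sapiens) as the target, read by MTT assay, with a stated time of 48 h; on this read-out higher numbers stand for weaker inhibition and lower numbers for stronger inhibition. Compound 1 `COc1cc(/C=N/Nc2nc(-c3ccc(F)c(F)c3)cs2)c(Br)c(Br)c1OC` gives 19600 nM in this assay. Compound 2 `COc1cc(/C=N/Nc2nc(-c3ccccc3)cs2)c(Br)c(Br)c1OC` gives 20100 nM in this assay. For the measured compounds named here, the only step between them, a 1.0-fold higher number from compound 1 to compound 2 (0.01 log units; within the scatter), changes just the ring that hangs from the core, and it moves the number by less than the scatter of repeated runs. Compound 2 therefore stands beside compound 1, the two values being indistinguishable by this measure.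

Compound 3 `COc1ccccc1-c1csc(N/N=C/c2cc(OC)c(OC)c(Br)c2Br)n1` is not yet measured. It differs from compound 2 by a single change: methoxy in place of hydrogen on an aromatic carbon. This alteration again touches only the hanging ring, the same region that the step from compound 1 to compound 2 altered without effect beyond the scatter. Going by the values given here, that step is the sole piece of evidence that bears on the new compound, and it was flat. The expectation is therefore a step of a 1.0-fold lower number from compound 2 to compound 3 (0.00 log units; within the scatter), that is, none beyond the scatter. Compound 3 is accordingly estimated at 20000 nM in this assay, within a range of 7000 nM to 60000 nM.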

Compound 3, half-maximal inhibitory concentration: > 100000 nM
Compound 3: no number, only a limit; the forecaster's own chance of this, stated with the estimate: 10%; middle value at least 5.0-fold (0.69 log units) away from the limit.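

In this assay, compound 3 gives no number, only a limit: the limit of > 100000 nM in this assay, at which 1 of the 3 values shown sits. Methoxy in place of hydrogen, ortho to a large group, produces an at least 4.9-fold higher number from compound 2 to compound 3 (0.69 log units; beyond the scatter), and 2-methoxyphenyl in place of 3,4-difluorophenyl produces an at least 5.1-fold higher number from compound 1 to compound 3 (0.70 log units; beyond the scatter). Both steps are lower bounds on the true size, and they show what compound 1 and compound 2 could not: the hanging ring is not indifferent to every change, since this single added group weakens inhibition beyond the scatter, whereas the earlier swap on that ring did not.

The compounds shown cannot tell whether this weakening belongs to the methoxy group itself or to its place on the ring, and they do not explain why it occurs. A hydroxyl, an amine or a longer chain such as ethoxy at this same place, or methoxy on another carbon of the ring, would be needed to separate these possibilities.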